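Saturated side-chain swap: from compound 2 to compound 3

The source may report more compounds than this note shows. Statements on the series, on what has been measured and on what is new or still open speak of the compounds shown alone.

Measured so far:
compound 1, `O=C(O)c1ccccc1-c1ccc(CCc2ncc(CC3CCCC3)[nH]2)cc1`: 133 nM
compound 2, `O=C(O)c1ccccc1-c1ccc(CCc2ncc(Cc3ccc(F)cc3)[nH]2)cc1`: 1600 nM

In an in vitro functional assay on cells for agonist activity at Bombesin receptor subtype-3 (Homo sapiens), read by luminescence and calcium flux (on this read-out higher numbers stand for an effect only at larger amounts of compound and lower numbers for an effect already at smaller amounts), compound 2 gives 1600 nM and stands highest of the two numbers; compound 1, the nearest, gives 133 nM. Among the compounds with values here, the single step at hand, a 12-fold higher number from compound 1 to compound 2 (1.08 log units; beyond the scatter), replaced a saturated ring by an aromatic one at the same position. Compound 3, `CC(C)CCc1cnc(CCc2ccc(-c3ccccc3C(=O)O)cc2)[nH]1`, carries the change (isobutyl in place of 4-fluorophenyl on a saturated chain carbon bound to an aromatic carbon), which removes that aromatic ring again for an acyclic chain. Within the data shown here, since the only measured step went up by a large amount on introducing the aromatic ring, a step down of comparable but uncertain size is expected here, a 5.3-fold lower number from compound 2 to compound 3 (0.73 log units; beyond the scatter). For compound 3 the estimate is 300 nM, range 100 nM to 1000 nM.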

Compound 3, half-maximal effective concentration: 119 nM
Compound 3: the middle estimate sits 2.5-fold (0.40 log units) above what was measured; the measured number falls inside the stated range.
By their numbers in this assay, from the lowest: compounds 3 and 1 (each within the scatter of the next); then compound 2.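

In this assay the isobutyl group undoes the loss seen with 4-fluorophenyl, with a 13-fold lower number from compound 2 to compound 3 (1.13 log units; beyond the scatter) as the step on a saturated chain carbon bound to an aromatic carbon. With a 1.1-fold lower number from compound 1 to compound 3 (0.05 log units; within the scatter) as the comparison, isobutyl and cyclopentyl read alike, so a saturated ring is not needed here and, of the three groups, only 4-fluorophenyl stands apart. Nothing available accounts for this difference. On these data alone, whether the higher number of compound 2 goes with the aromatic ring or with its fluorine remains open. As far as these compounds go, how an unsubstituted phenyl, an amine or a longer chain would read here also remains open.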